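Ring swap on the triple-bonded carbon: compound 2 to compound 3

A few compounds are considered here, and "the series" means these few. Any claim that something is new, unique, unknown or untested is made for them only; others in the source may bear on it.

Two compounds of the series have numbers in an assay on HEK293 cells for displacement of a labelled ligand from adenosine receptor A3 (Mus musculus), read by scintillation counting, with a stated time of 60 min; on this read-out lower numbers stand for stronger inhibition and higher numbers for weaker inhibition. Compound 1 `CNC(=O)[C@@]12C[C@@H]1[C@@H](n1cnc3c(NC)nc(C#Cc4ncccn4)nc31)[C@H](O)[C@@H]2O` gives 65 nM. Compound 2 `CNC(=O)[C@@]12C[C@@H]1[C@@H](n1cnc3c(NC)nc(C#Cc4cccnn4)nc31)[C@H](O)[C@@H]2O` gives 112 nM. For the measured compounds named here, the one measured step, a 1.7-fold higher number from compound 1 to compound 2 (0.24 log units; within the scatter), exchanges one six-membered aromatic ring with two hetero atoms for another on the triple-bonded carbon and stays within the scatter. Going by the values given here, on the numbers so far, compound 2 and compound 1 sit inside the scatter of each other, so neither can be called the weaker of the two.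

Compound 3 `CNC(=O)[C@@]12C[C@@H]1[C@@H](n1cnc3c(NC)nc(C#Cc4cnn(C)c4)nc31)[C@H](O)[C@@H]2O` differs from compound 2 only by 1-methyl-1H-pyrazol-4-yl in place of pyridazin-3-yl on a triple-bonded carbon. A six-membered ring leaves and a five-membered ring enters, with the same counts of heavy atoms and hydrogen-bond acceptors. Among the compounds with values here, only the step from compound 1 to compound 2 bears on this change, and it was within the scatter; no measured step reports a five-membered ring at this place. Accordingly a step of about a 1.2-fold higher number from compound 2 to compound 3 (0.06 log units; within the scatter) is expected in this assay, nothing beyond the scatter. Compound 3 is estimated at 130 nM, with a range from 40 nM to 400 nM.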

Compound 3, inhibition constant: 126 nM
For compound 3 the middle estimate is 1.0-fold (0.01 log units) above the measured one; measured number inside the range.
By their numbers in this assay, from the lowest: compounds 1, 2 and 3 (each within the scatter of the next).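

In this assay, a five-membered ring on the triple-bonded carbon reads the same as the six-membered rings within the scatter: 1-methyl-1H-pyrazol-4-yl against pyridazin-3-yl gives a step (a 1.1-fold higher number from compound 2 to compound 3 (0.05 log units; within the scatter)), and against pyrimidin-2-yl it gives a step (a 1.9-fold higher number from compound 1 to compound 3 (0.29 log units; within the scatter)). Across these three compounds, therefore, neither ring size nor the methyl group carried by the ring in compound 3 separates the numbers, although all three rings have the same count of hetero atoms. No measurement is available that would explain this result.

The compounds shown leave open whether a phenyl ring, which has no hetero atoms, or a non-aromatic group such as an aminomethyl or a carboxylic acid on the triple-bonded carbon would move the number beyond the scatter. Going by these compounds, it is also open whether the methyl group on the pyrazole matters at all, which the unsubstituted 1H-pyrazol-4-yl ring or a longer chain such as 1-propyl-1H-pyrazol-4-yl would test.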